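From fluoro to cyano on the benzyl ester

This account rests on a few compounds, and the source may have more. Where it says the series, first, only, none or still open, it means among the compounds named here.

Measured in an assay on isolated protein for inhibition of protein kinase C zeta type (Homo sapiens), with stated times of 1 h and 2.5 min, tested at 30 uM; on this read-out higher numbers stand for more inhibition at the one concentration tested (going by the name of the read-out) and lower numbers for less inhibition:
compound 1, `COc1ccc(-c2csc(N)c2C(=O)OCc2ccccc2C)cc1OC`: 64%
compound 2, `COc1ccc(-c2csc(N)c2C(=O)OCc2cccc(C)c2)cc1OC`: 67%
compound 3, `COc1ccc(-c2csc(N)c2C(=O)OCc2ccc(F)cc2)cc1OC`: 2%

Compound 3 stands lowest of the three. The steps of a number 62 percentage points lower from compound 1 to compound 3 (beyond the scatter) and a number 65 percentage points lower from compound 2 to compound 3 (beyond the scatter) are both large and beyond the scatter, whereas a number 3 percentage points higher from compound 1 to compound 2 (within the scatter) lies within it. Compound 4, `COc1ccc(-c2csc(N)c2C(=O)OCc2ccc(C#N)cc2)cc1OC`, differs from compound 3 by cyano in place of fluoro on an aromatic carbon. For the measured compounds named here, no measured step exchanges one group for another at this place, para to a large group; the two large steps only show that the 4-fluorobenzyl ester sits far below the methyl-bearing esters. The change is therefore expected to leave the number near the low level of compound 3, a step of a number 8 percentage points higher from compound 3 to compound 4 (within the scatter). Compound 4 is expected to give 10% in this assay, between 0% and 40%.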

Compound 4, a percentage reported as inhibition, at one concentration (the size of the read-out at that concentration, not a potency): 10%
Compound 4: the middle estimate sits on the measured number at the digits printed; the range from low to high includes it.
By their numbers in this assay, from the lowest: compounds 3 and 4 (each within the scatter of the next); then compounds 1 and 2 (each within the scatter of the next).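

In this assay the exchange on this aromatic carbon, para to a large group, gives a number 8 percentage points higher from compound 3 to compound 4 (within the scatter) and so leaves the number at its low level. The compounds with the 4-cyanobenzyl and 4-fluorobenzyl esters therefore stay together, and the methyl-bearing esters remain far apart from compound 4, with a number 57 percentage points lower from compound 2 to compound 4 (beyond the scatter) and a number 54 percentage points lower from compound 1 to compound 4 (beyond the scatter) as the steps. Nothing at hand accounts for this low level. As far as these compounds go, whether a methyl group at this same place would give a higher number stays open. So does the outcome with an amine or a carboxylic acid here.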